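The source may report more compounds than this note shows. Statements on the series, on what has been measured and on what is new or still open speak of the compounds shown alone.

Measured compounds:
compound 1 `CCCn1c(-c2ccccc2)nc2c(NC3CCOC3)ncnc21` — 2810 nM
compound 2 `Cn1c(-c2ccc(O)cc2)nc2c(NC3CCCC3)ncnc21` — 521 nM

Among the measured compounds shown here, in an assay on CHO cells for displacement of a labelled ligand from adenosine receptor A3 (Homo sapiens), read by scintillation counting, with a stated time of 3 h (on this read-out higher numbers stand for weaker inhibition and lower numbers for stronger inhibition), compound 2 gives 521 nM, the lower of the two numbers measured so far; compound 1 gives a higher number, and the gap between the two lies beyond the scatter. Compound 3 `Cc1ccccc1-c1nc2c(NC3CCCC3)ncnc2n1C` has not yet been measured. It differs from compound 2 in one place: 2-methylphenyl in place of 4-hydroxyphenyl on an aromatic carbon. No step of this kind has been measured among the compounds shown, so the size and direction of the change can only be guessed. The hydrogen-bond donor and acceptor of the 4-hydroxyphenyl group are lost, while a methyl enters on the ring, and on this basis compound 3 is expected to come out somewhat weaker than compound 2, with a step of a 2.3-fold higher number from compound 2 to compound 3 (0.36 log units; beyond the scatter) in this assay. The estimate for compound 3 is 1200 nM, within a range of 300 nM to 5000 nM.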

Compound 3, inhibition constant: 3000 nM
Estimate against measurement, compound 3: 2.5-fold (0.40 log units) below; the measured number falls inside the stated range.
By their numbers in this assay, from the lowest: compound 2; then compounds 1 and 3 (each within the scatter of the next).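

In this assay, placing 2-methylphenyl in place of 4-hydroxyphenyl on the aromatic carbon between two ring nitrogen atoms gives a 5.8-fold higher number from compound 2 to compound 3 (0.76 log units; beyond the scatter) as the first single change read in this series. This shows that the position responds to the exchange of these two groups by more than the scatter, with the rest of compound 2 unchanged. The exchange removes the hydroxyl and adds the methyl together, so the step cannot be divided between them, and no supporting measurement bears on why the number rises.

A plain phenyl or a 4-methoxyphenyl group on the same carbon of the core of compound 2 would help separate those two parts of the change. As far as these compounds go, it also remains open whether the step would persist with an ethyl chain in place of the methyl group on the neighbouring ring atom.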